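The source may report more compounds than this note shows. Statements on the series, on what has been measured and on what is new or still open speak of the compounds shown alone.

Compound 1, `Cc1ccc(NC(=O)c2cccc(C(F)(F)F)c2)cc1OC1CCN(C(=O)c2ccncc2)CC1`, opens the set, and in an ADME assay on BaF3 cells (Mus musculus) for antiproliferative activity (a higher number here means a weaker inhibitor of growth, a lower number a stronger inhibitor of growth), compound 1 reaches only a limit, > 10000 nM. Compound 2, `COc1ccc(NC(=O)c2cccc(C(F)(F)F)c2)cc1OC1CCN(C(=O)c2cccnc2)CC1`, is a close relative, and in this assay compound 2 likewise reaches only a limit, > 10000 nM. Going by the values given here, compound 3, `Cc1ccc(NC(=O)c2ccc(C)c(C(F)(F)F)c2)cc1OC1CCN(C(=O)c2ccncc2)CC1`, is the one member with a number: in this assay compound 3 gives 6390 nM. Among the compounds with values here, the only measured step is an at least 1.5-fold lower number from compound 1 to compound 3 (0.19 log units; that floor lies within the scatter), and since its floor lies within the scatter, it shows no more than that compound 3 yields a value where the others do not, as the limit of > 10000 nM in this assay, at which 2 of the 3 values shown sit, makes plain.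

Compound 4, `Cc1ccc(NC(=O)c2ccc(C)c(C(F)(F)F)c2)cc1OC1CCN(C(=O)c2cncs2)CC1`, carries 1,3-thiazol-5-yl in place of pyridin-4-yl on a carbonyl carbon. Within the data shown here, no measured step touches an exchange of this kind, so the data give no direction for it. The expectation is therefore no step beyond the scatter, a 1.1-fold lower number from compound 3 to compound 4 (0.03 log units; within the scatter). In this assay compound 4 is expected at 6000 nM, with a range from 2000 nM to 20000 nM, and a real chance remains that only a limit is reported.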

Compound 4, concentration for 50% growth inhibition: > 10000 nM
Compound 4 ended at the assay's limit; the forecaster's own chance of this, stated with the estimate: 35%; at least 1.6-fold (0.22 log units) between middle value and limit.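

Going by these compounds alone, the first measured exchange on this carbonyl carbon, 1,3-thiazol-5-yl in place of pyridin-4-yl, gives an at least 1.5-fold higher number from compound 3 to compound 4 (0.19 log units; that floor lies within the scatter). Within the data shown here, since that floor lies within the scatter, the exchange cannot be called a real loss of growth inhibition; it shows only that this five-membered ring does not keep a measurable value in this assay. Among these compounds, compound 3 therefore remains the only member with a number, and the rest of the set sits at a limit of the assay: the limit of > 10000 nM in this assay, at which 3 of the 4 values shown sit.

From the compounds shown here alone, how far compound 4 lies past its limit stays unknown, so the size of this exchange cannot be read. Compound 3 gives 6390 nM, and the compounds shown also leave open whether an amine or a carboxylic acid on this carbonyl carbon would give a lower number.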